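The source may report more compounds than this note shows. Statements on the series, on what has been measured and on what is new or still open speak of the compounds shown alone.

Measured compounds:
compound 1 `ClCc1ccccc1Cn1cnc2c(Cl)nc(Cl)nc21` — 150 nM
compound 2 `ClCc1ccccc1Cn1cnc2c(Cl)ncnc21` — 1770 nM

Within the data shown here, in a functional assay on SW-620 cells (Homo sapiens) for cytotoxicity, read by sulforhodamine B assay, with a stated time of 48 h (on this read-out higher numbers stand for weaker inhibition of growth and lower numbers for stronger inhibition of growth), compound 2 stands highest of the two numbers; its nearest neighbour is compound 1, and the only measured step is a 12-fold higher number from compound 1 to compound 2 (1.07 log units; beyond the scatter). Compound 3 `Nc1nc(Cl)c2ncn(Cc3ccccc3CCl)c2n1` differs from compound 2 by amino in place of hydrogen on an aromatic carbon. That single measured step concerns a chloro group at another place and does not bear directly on an added amino group, so nothing measured here sets the direction. The expected step is therefore a 1.2-fold lower number from compound 2 to compound 3 (0.07 log units; within the scatter), within the scatter. Compound 3 is estimated at 1500 nM, with a range from 450 nM to 5000 nM.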

Compound 3, concentration for 50% growth inhibition: 3310 nM
For compound 3 the middle estimate is 2.2-fold (0.34 log units) below the measured one; low and high end bracket the measured number.
By their numbers in this assay, from the lowest: compound 1; then compounds 2 and 3 (each within the scatter of the next).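

In this assay, amino in place of hydrogen on the aromatic carbon between two ring nitrogen atoms gives a 1.9-fold higher number from compound 2 to compound 3 (0.27 log units; within the scatter), so at this position the amino group cannot be told apart from hydrogen. Amino in place of chloro on that carbon gives a 22-fold higher number from compound 1 to compound 3 (1.34 log units; beyond the scatter), so of the three groups shown here, only chloro goes with the low number. No evidence is given that would explain this.

The compounds shown leave open whether a bromo or methoxy group on this carbon would stay with chloro or with amino and hydrogen. They also leave open what a methyl group in place of the chloromethyl group would do to these numbers.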